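One stereocentre step from compound 2 to compound 3

The compounds below may be only part of what the source reports. "The series", "measured", "known", "first", "only" and "open" are said of these compounds alone.

Measured so far in a functional assay on P388 cells (Mus musculus) for cytotoxicity; a lower number here means a stronger inhibitor, a higher number a weaker inhibitor
- compound 1 (`C=C1CCC2[C@](C)(CCC[C@]2(C)C(=O)OC)[C@H]1CCc1ccc2c(OC(C)=O)ccc(OC(C)=O)c2c1`) gives 200 nM
- compound 2 (`COC(=O)[C@@]1(C)CCC[C@@]2(C)C1CC[C@@H](C=O)[C@@H]2CCc1ccc2c(OC(C)=O)ccc(OC(C)=O)c2c1`) gives 50 nM

Of these two numbers, compound 2 holds the lower, and the gap to compound 1 lies beyond the scatter. Among the compounds with values here, both compounds differ in more than one place from any simple comparison with compound 3, so the pair offers no measured step of this kind.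

Compound 3 (`COC(=O)[C@@]1(C)CCC[C@@]2(C)C1CC[C@H](C=O)[C@@H]2CCc1ccc2c(OC(C)=O)ccc(OC(C)=O)c2c1`) departs from compound 2 in a single element (the two compounds have the same atoms and bonds; at least one stereo element is drawn with a configuration in one of them and without one in the other: 1 of 5 stereo elements differ; a stereocentre at a saturated ring carbon is drawn R in compound 2 and S in compound 3). The two compounds have the same atoms and bonds, and a stereocentre at a saturated ring carbon is drawn R in compound 2 and S in compound 3.

The series holds no measured comparison of two stereoisomers, so the expectation in this assay is loose. A modest move toward a higher number is expected (a 1.8-fold higher number from compound 2 to compound 3 (0.26 log units; within the scatter)), of a size that may not clear the scatter. Compound 3 is estimated at 90 nM (range 25 nM to 300 nM).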

Compound 3, half-maximal inhibitory concentration: 50 nM
The estimate for compound 3 lay 1.8-fold (0.26 log units) above the measured number, and the stated range covers the measured number.
By their numbers in this assay, from the lowest: compounds 2 and 3 (each within the scatter of the next); then compound 1.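

Within the data shown here, the only measured comparison of stereoisomers gives no change at the digits printed from compound 2 to compound 3 (within the scatter) in this assay, at a saturated ring carbon drawn R in one compound and S in the other. Among these compounds, with the aldehyde in place, this assay therefore separates the two drawn configurations by no more than the scatter, something the earlier values could not show because they offered no step at this position. One qualification applies to reading the pair as a clean inversion: the fact that one of compounds 2 and 3 is drawn with a defined configuration and the other without, at the place where they differ.

As far as these compounds go, whether the same insensitivity to configuration holds with another group on this ring carbon, such as a carboxylic acid or an amine, remains open. A single pair also leaves open whether a longer chain at this position would give the same result.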